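The compounds below may be only part of what the source reports. "The series", "measured", "known", "first", "only" and "open" are said of these compounds alone.

Measured compounds:
compound 1 `N=C(Nc1cccc(C(F)(F)F)c1)c1cc2cn[nH]c2cn1`: 36500 nM
compound 2 `CN1CCN(c2ccc(NC(=N)c3cc4c(-c5ccccc5)n[nH]c4cn3)cc2)CC1`: 11400 nM
compound 3 `CN1CCN(c2ccc(NC(=N)c3cc4c(-c5ccccc5)nn(C)c4cn3)cc2)CC1`: 1400 nM

In a functional assay on HT-1080 cells (Homo sapiens) for cytotoxicity, read by MTT assay, with a stated time of 72 h (a higher number here means a weaker inhibitor, a lower number a stronger inhibitor), compound 1 gives the highest of the three numbers; the difference between its core and that of compound 2 is not broken down here. Between compound 2 and compound 3 the change is methyl in place of hydrogen on an aromatic nitrogen, and it gave an 8.1-fold lower number from compound 2 to compound 3 (0.91 log units; beyond the scatter). Compound 4 `Cn1ncc2cc(C(=N)Nc3cccc(C(F)(F)F)c3)ncc21` is not yet measured; it is made from compound 1 by methyl in place of hydrogen on an aromatic nitrogen. This is the same kind of change, but the surroundings differ: in compound 3 the place is two ring bonds from the ring atom that bears a phenyl group, and compound 4 has no such group. Resting on the single earlier step from compound 2 to compound 3, compound 4 is expected to show a 4.6-fold lower number from compound 1 to compound 4 (0.66 log units; beyond the scatter), a somewhat smaller step. The setting is not identical, and the expectation is kept somewhat below the earlier step for that reason. Compound 4 is thus estimated at 8000 nM, between 3000 nM and 25000 nM.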

Compound 4, half-maximal inhibitory concentration: 33800 nM
Beside the measured number, compound 4's estimate is 4.2-fold (0.63 log units) below it, and the stated range ends below it.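

In this assay, methyl in place of hydrogen on an aromatic nitrogen gave a 1.1-fold lower number from compound 1 to compound 4 (0.03 log units; within the scatter), so the step seen on the other core did not carry over to the core of compound 1: the same change on two cores in this assay, an 8.1-fold lower number (0.91 log units; beyond the scatter) from compound 2 to compound 3 and a 1.1-fold lower number (0.03 log units; within the scatter) from compound 1 to compound 4, 7.5-fold (0.88 log units) apart, beyond the scatter of two such steps. The size of this step therefore depends on the surroundings, at least in these two pairs. The pairs do not show which difference is responsible, since compound 2 and compound 3 differ from compound 1 and compound 4 both in the phenyl group and in the rest of the molecule.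

As far as these compounds go, it remains open whether an ethyl group or a longer chain on the same nitrogen would behave like methyl on either core. Also open, from the compounds shown here alone, is whether adding the phenyl group alone to compound 1 would bring back the larger step.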